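Fluoro to methyl on the fluorophenyl arm of compound 1

A few compounds are considered here, and "the series" means these few. Any claim that something is new, unique, unknown or untested is made for them only; others in the source may bear on it.

Measured so far:
compound 1, `Fc1ccc(C2=NN(c3nc(-c4ccccc4)cs3)C(c3cccs3)C2)cc1`: 170 nM
compound 2, `Fc1ccc(C2=NN(c3nc(-c4ccc(C(F)(F)F)cc4)cs3)C(c3cccs3)C2)cc1`: 5120 nM

In a functional assay on WM 266-4 cells (Homo sapiens) for antiproliferative activity, read by MTT assay, with a stated time of 48 h (on this read-out lower numbers stand for stronger inhibition and higher numbers for weaker inhibition), compound 1 gives the lower of the two numbers shown; its nearest neighbour is compound 2, and the step of a 30-fold higher number from compound 1 to compound 2 (1.48 log units; beyond the scatter) is the only measured step in the series so far. That step concerns a trifluoromethyl entering in place of hydrogen on an aromatic carbon, a change at a different site from the one considered here.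

Compound 3, `Cc1ccc(C2=NN(c3nc(-c4ccccc4)cs3)C(c3cccs3)C2)cc1`, differs from compound 1 as follows: methyl in place of fluoro on an aromatic carbon. Among the compounds with values here, no measured step touches this change; the step from compound 1 to compound 2 belongs to another ring and gives no direct guide. Methyl and fluoro are both single heavy atoms, neither bearing a donor or acceptor, so the change is small in what is counted. The expectation is therefore a step close to the scatter, with weakening no more likely than strengthening.

For compound 3 the expected value in this assay is 300 nM, with a range from 80 nM to 1200 nM. This corresponds to an expected step of a 1.8-fold higher number from compound 1 to compound 3 (0.25 log units; within the scatter).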

Compound 3, half-maximal inhibitory concentration: 7520 nM
For compound 3 the middle estimate is 25-fold (1.40 log units) below the measured one; measured number above the stated range.
By their numbers in this assay, from the lowest: compound 1; then compounds 2 and 3 (each within the scatter of the next).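

In this assay, the change from 4-fluorophenyl to 4-methylphenyl gives a 44-fold higher number from compound 1 to compound 3 (1.65 log units; beyond the scatter), so this place, on an aromatic carbon para to a large group, does not tolerate every swap of one heavy atom for another. Fluoro and methyl match in everything counted here (heavy atoms, hydrogen-bond donors and acceptors, net charge), so those counts do not separate a compound near the top of this short series from one with a much higher number. With a 30-fold higher number from compound 1 to compound 2 (1.48 log units; beyond the scatter) at a different site, both single changes shown away from compound 1 now raise the number beyond the scatter, none of the steps shown goes against this, and no measurement bears on why the methyl step is so large.

The compounds shown leave open whether the fluoro is itself needed or the methyl is what costs activity, a question that hydrogen, chloro, methoxy or an amine at this same place would help to settle. Also open, going by these compounds, is whether a longer chain at this place would follow the methyl, and whether this step holds with other groups on the remaining rings of the core.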